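Same atoms, joined differently, in compound 3

The source may hold more compounds than are shown below. What is called first, only, known or untested is meant among the compounds shown, and "the series" means these compounds.

In a functional assay (blood) for inhibition, with Homo sapiens as the target (on this read-out lower numbers stand for stronger inhibition and higher numbers for weaker inhibition), compound 1 `COC(C)c1cc(-c2ccccc2)c2ccc(OCc3cccc(C4(O)CCOCC4)c3)cc2c1` reads > 1000 nM, which is a limit of the assay and not a number. Among the compounds with values here, compound 2 `Cn1nnc(-c2cc(-c3ccccc3)c3ccc(OCc4cccc(C5(O)CCOCC5)c4)cc3c2)n1` gives 310 nM, the only exact number so far. Putting 2-methyl-2H-tetrazol-5-yl in place of 1-methoxyethyl on an aromatic carbon produced an at least 3.2-fold lower number from compound 1 to compound 2 (0.50 log units; beyond the scatter). Within the data shown here, compound 3 `Cn1nnnc1-c1cc(-c2ccccc2)c2ccc(OCc3cccc(C4(O)CCOCC4)c3)cc2c1` keeps everything else and alters only that group: 1-methyl-1H-tetrazol-5-yl in place of 2-methyl-2H-tetrazol-5-yl on an aromatic carbon. Here 1-methyl-1H-tetrazol-5-yl takes the place of 2-methyl-2H-tetrazol-5-yl, with the same atoms joined differently. Among the measured compounds shown here, the single measured step, an at least 3.2-fold lower number from compound 1 to compound 2 (0.50 log units; beyond the scatter), swapped in a wholly different group, so it gives only a loose guide to a change this small. No direction can be read from it, and no shift beyond the scatter is expected in this assay. The estimated move is a 1.1-fold higher number from compound 2 to compound 3 (0.05 log units; within the scatter). For compound 3 the expected value is 350 nM, with an estimated range of 130 nM to 900 nM.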

Compound 3, half-maximal inhibitory concentration: > 10000 nM
Compound 3 gave a limit, no number; the forecaster's own chance of this, stated with the estimate: 10%; middle value at least 28-fold (1.45 log units) away from the limit.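

In this assay, this place on the aromatic ring responds not only to which group sits there but also to how that group is joined: 1-methyl-1H-tetrazol-5-yl in place of 2-methyl-2H-tetrazol-5-yl, with the same atoms and the same counts of donors and acceptors, gives an at least 32-fold higher number from compound 2 to compound 3 (1.50 log units; beyond the scatter). The earlier step from compound 1 to compound 2 swapped two wholly different groups, so it could not show that a rearrangement alone matters this much. Compound 3 gives a limit of the assay, not a number: the limit of > 10000 nM in this assay, at which 1 of the 3 values shown sits.

The step between compound 1 and compound 3 cannot be read, and the values shown give no cause for the weaker result of compound 3. On these data alone, whether another ring at this place, such as a 1,2,4-oxadiazole or a 1,2,3-triazole, or a carboxylic acid, would read closer to compound 2 or to compound 3 remains open.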